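Swapping a Pyridine Arm for a Third Thiophene

A few compounds are considered here, and "the series" means these few. Any claim that something is new, unique, unknown or untested is made for them only; others in the source may bear on it.

Three measured compounds share a frame of linked aromatic rings: compound 1 `C(=C/c1cccs1)\c1cc(-c2cccs2)cc(-c2cccs2)n1`, compound 2 `c1ccc(-c2cc(-c3cccs3)nc(-c3cccs3)c2)nc1` and compound 3 `c1ccc(-c2cc(-c3ccco3)ccn2)nc1`. In a functional assay on A549 cells (Homo sapiens) for antiproliferative activity (on this read-out lower numbers stand for an effect already at smaller amounts and higher numbers for an effect only at larger amounts of compound), compound 2 gives 118000 nM. In this assay compound 1 gives 118000 nM and compound 3 gives 118000 nM, so compound 2 stands level with both at the digits shown, all three values lying within the usual scatter of one another. Compound 4 `c1csc(-c2cc(-c3cccs3)nc(-c3cccs3)c2)c1` differs from compound 2 in one place: thiophen-2-yl in place of pyridin-2-yl on an aromatic carbon. Going by the values given here, no step between measured compounds shows what such a swap does, and since all three values sit together, no step beyond the scatter is expected. Compound 4 is therefore estimated at 118000 nM in this assay, between 55000 nM and 250000 nM. The expected step of no change at the digits printed from compound 2 to compound 4 (within the scatter) is none beyond the scatter.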

Compound 4, half-maximal effective concentration: 118000 nM
Estimate against measurement, compound 4: no gap at the digits printed; measured number inside the range.
By their numbers in this assay, from the lowest: compounds 1, 2, 3 and 4 (each within the scatter of the next).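

In this assay, no change at the digits printed from compound 2 to compound 4 (within the scatter) comes with thiophen-2-yl in place of pyridin-2-yl on the aromatic carbon opposite the ring nitrogen, so these two rings cannot be told apart at this position. Likewise, no change at the digits printed from compound 1 to compound 4 (within the scatter) comes with thiophen-2-yl in place of 2-(thiophen-2-yl)ethenyl on an aromatic carbon. Nothing measured here explains why these values stay level. Still open, going by these compounds, is whether a non-ring group at the carbon opposite the ring nitrogen, such as an amine or a carboxylic acid, would move the value away from that of compound 4 .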